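The source may report more compounds than this note shows. Statements on the series, on what has been measured and on what is new or still open speak of the compounds shown alone.

Compound 3, with the structure `CC1=C(C(=O)OCC(C)C)C(c2ccsc2)NC(=S)N1`, is the starting point here. In an assay on membranes from CHO cells for displacement of a labelled ligand from adenosine receptor A1 (Homo sapiens), read by scintillation counting, with a stated time of 60 min, tested at 1 uM (a higher number here means more inhibition at the concentration tested (going by the name of the read-out), a lower number less inhibition), compound 3 gives 8%. Among the three compounds measured, its number is neither the highest nor the lowest: compound 2 `CCCOC(=O)C1=C(C)NC(=S)NC1c1ccsc1` gives 5%, and compound 1 `CC1=C(C(=O)OC(C)(C)C)C(c2ccoc2)NC(=S)N1` gives 18%, and the gap from compound 3 to each of these lies within the usual scatter, so no real difference among the three can be claimed.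

The next compound, compound 4 `CC1=C(C(=O)OC(C)(C)C)C(c2ccsc2)NC(=S)N1`, has not yet been measured. It differs from compound 3 only at the ester: tert-butyl in place of isobutyl on an oxygen next to a carbonyl group.

Going by the values given here, only one measured step alters this same part of the molecule, the change of the ester chain from compound 2 to compound 3, which gave a number 3 percentage points higher from compound 2 to compound 3 (within the scatter). Compound 1 also carries a tert-butyl ester, and its value in this assay is 18%, but its ring is a different one, so only its number, not a step, can be set beside compound 3. Taken together, the ester chain has so far moved the inhibition little. The step from compound 3 to compound 4 is therefore expected to be small, a number 5 percentage points higher from compound 3 to compound 4 (within the scatter), and not beyond the scatter. Compound 4 is estimated to give 13% in this assay, with a range from 2% to 28%.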

Compound 4, a percentage reported as inhibition, at one concentration (the size of the read-out at that concentration, not a potency): 16%
Beside the measured number, compound 4's estimate is 3 percentage points below it; the measured number falls inside the stated range.
By their numbers in this assay, from the lowest: compounds 2, 3, 4 and 1 (each within the scatter of the next, the first and the last beyond it).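

In this assay, tert-butyl in place of isobutyl on an oxygen next to a carbonyl group keeps the same carbon count and only joins the atoms differently, and this gives a number 8 percentage points higher from compound 3 to compound 4 (within the scatter), so this rearrangement alone cannot be told apart from repeat-to-repeat variation. Tert-butyl in place of propyl at the same place gives a number 11 percentage points higher from compound 2 to compound 4 (beyond the scatter), the first step at this position to pass the scatter, though the change is only modest. With the tert-butyl ester held constant, thiophen-3-yl in place of furan-3-yl on a saturated ring carbon gives a number 2 percentage points lower from compound 1 to compound 4 (within the scatter), so this ring swap shows no real effect on the read-out.

Still open, from the compounds shown here alone, is whether a longer chain on the ester oxygen, or an amide or a carboxylic acid in place of the ester, would move the inhibition further, since these readings come from a single concentration and say nothing about potency. No measurement shown accounts for the difference between the propyl and tert-butyl esters.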